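Fluoro added to a thiourea bearing a chloro substituent

A few compounds are considered here, and "the series" means these few. Any claim that something is new, unique, unknown or untested is made for them only; others in the source may bear on it.

Compound 1, `Fc1ccc(NC(=S)Nc2nc3ccccc3s2)cc1`: in a functional assay on U-937 cells (Homo sapiens) for cytotoxicity, read by MTT assay, with a stated time of 48 h (on this read-out higher numbers stand for weaker inhibition and lower numbers for stronger inhibition), compound 1 gives 32100 nM.
Compound 2, `S=C(Nc1ccccc1)Nc1nc2c(Cl)cccc2s1`: in this assay compound 2 gives only the assay limit > 50000 nM.
Compound 3, `S=C(Nc1ccccc1)Nc1nc2ccccc2s1`: in this assay compound 3 gives only the assay limit > 50000 nM.

Compound 2 therefore has no number of its own; it sits at the limit of > 50000 nM in this assay, at which 2 of the 3 values shown sit. The compound not yet measured is compound 4, `Fc1ccc(NC(=S)Nc2nc3c(Cl)cccc3s2)cc1`, which differs from compound 2 by fluoro in place of hydrogen on an aromatic carbon.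

One measured step speaks to this change, read backwards: an at least 1.5-fold higher number from compound 1 to compound 3 (0.19 log units; that floor lies within the scatter), a step whose floor lies within the usual scatter. The other neighbouring step, a step that the two limits leave unreadable from compound 2 to compound 3, gives no size at all, since both ends are limits. So the only guidance is that adding fluoro to the shared core without the chloro group lowered the number, at least a little, from a limit to a measured value.

Starting from a limit, a modest lowering is the expectation for compound 4, though it may well remain at the limit: compound 4 is estimated at 45000 nM, with a range from 20000 nM to 120000 nM. That estimate means an expected step of an at least 1.1-fold lower number from compound 2 to compound 4 (0.04 log units; that floor lies within the scatter).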

Compound 4, half-maximal inhibitory concentration: > 50000 nM
Compound 4 gave a limit, no number (the forecaster's own chance of this, stated with the estimate: 55%); at least 1.1-fold (0.04 log units) between middle value and limit.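

The new compound shows that the phenyl to 4-fluorophenyl change does not behave the same way on every core: on the core without chloro, the 4-fluorophenyl compound 1 has a measured value, whereas adding fluoro to compound 2 still gives no number. In this assay, within the data shown here, the one readable comparison holds the 4-fluorophenyl group fixed and places chloro on the shared core, giving an at least 1.5-fold higher number from compound 1 to compound 4 (0.19 log units; that floor lies within the scatter), so this step's floor does not by itself establish a real loss of activity, even though a measured value has given way to a limit. Compound 2, compound 3 and compound 4 all stop at the same assay limit, and the steps among them cannot be read: the limit of > 50000 nM in this assay, at which 3 of the 4 values shown sit.

From the compounds shown here alone, what remains open is how far compound 2, compound 3 and compound 4 really lie from one another, and whether fluoro changes anything at all on the chloro-bearing core, since a limit hides any such difference. Also open, going by these compounds, is whether an amine or a carboxylic acid in place of the fluoro would bring the chloro-bearing core to a measured value in this cell assay.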